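The source may hold more compounds than are shown below. What is called first, only, known or untested is meant among the compounds shown, and "the series" means these compounds.

Three compounds share one core and differ only in the aryl group on a saturated chain carbon bound to an amine nitrogen. In a functional assay on HPAC cells (Homo sapiens) for inhibition, read by MTT assay, with a stated time of 72 h (a lower number here means a stronger inhibitor of growth, a higher number a weaker inhibitor of growth), compound 3 `O=S(=O)(NCCCNCc1cccc(Cl)c1)c1cc(C(F)(F)F)cc(C(F)(F)F)c1` gives 2700 nM. Compound 1 `O=S(=O)(NCCCNCc1ccc(C(F)(F)F)cc1)c1cc(C(F)(F)F)cc(C(F)(F)F)c1` gives 2700 nM, and compound 2 `O=S(=O)(NCCCNCc1cccc2ccccc12)c1cc(C(F)(F)F)cc(C(F)(F)F)c1` gives 2400 nM. The step of no change at the digits printed from compound 1 to compound 3 (within the scatter), the step of a 1.1-fold lower number from compound 1 to compound 2 (0.05 log units; within the scatter) and the step of a 1.1-fold higher number from compound 2 to compound 3 (0.05 log units; within the scatter) all stay within the scatter, so compound 3 stands level with compound 1 and close to compound 2. Compound 4 `O=S(=O)(NCCCNCc1ccc(Cl)cc1)c1cc(C(F)(F)F)cc(C(F)(F)F)c1` carries the difference (4-chlorophenyl in place of 3-chlorophenyl on a saturated chain carbon bound to an amine nitrogen). Going by the values given here, no measured step shifts a chlorine within the same ring, but since exchanging whole aryl groups produced nothing beyond the scatter, the step of no change at the digits printed from compound 3 to compound 4 (within the scatter) is expected to be flat. Compound 4 is therefore estimated at 2700 nM, between 1400 nM and 5400 nM.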

Compound 4, concentration for 50% growth inhibition: 2800 nM
Compound 4: the middle estimate sits 1.0-fold (0.02 log units) below what was measured; measured number inside the range.
By their numbers in this assay, from the lowest: compounds 2, 1, 3 and 4 (each within the scatter of the next).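

Moving the chlorine from 3-chlorophenyl to 4-chlorophenyl is the first change at this position that keeps the same atoms, and it gives a 1.0-fold higher number from compound 3 to compound 4 (0.02 log units; within the scatter), so the chlorine's place on this ring makes no visible difference here. Compound 4 also stays within the scatter of the other two aryl groups, with a 1.2-fold higher number from compound 2 to compound 4 (0.07 log units; within the scatter) and a 1.0-fold higher number from compound 1 to compound 4 (0.02 log units; within the scatter), the latter swapping trifluoromethyl for chloro on an aromatic carbon. Nothing available explains why these numbers stay so close. From the compounds shown here alone, whether a phenyl ring carrying an amine or a carboxylic acid, or a longer chain, would move the number remains open.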